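Adding Chloro to the Pyridin-2-yl Amide, Compound 4

The source may hold more compounds than are shown below. What is called first, only, known or untested is meant among the compounds shown, and "the series" means these compounds.

Measured in a functional assay on KB cells (Homo sapiens) for inhibition, read by MTT assay, with a stated time of 24 h, tested at 100 ug/mL; a higher number here means more inhibition of growth at the concentration tested, a lower number less inhibition of growth:
compound 1 `O=C(CCCCC1CCSS1)NO`: 12.4%
compound 2 `O=C(CCCCC1CCSS1)Nc1ccc(OC(F)(F)F)cc1`: 90.1%
compound 3 `O=C(CCCCC1CCSS1)Nc1ccccn1`: 25.1%

Of these three, compound 3 at 25.1% stands second highest, above compound 1 at 12.4%, while compound 2 at 90.1% exceeds compound 3. The next compound to be tested in this assay is compound 4 `O=C(CCCCC1CCSS1)Nc1ccc(Cl)cn1`. It differs from compound 3 by chloro in place of hydrogen on an aromatic carbon.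

Going by the values given here, no measured step covers this change directly. The only one available, a number 12.7 percentage points higher from compound 1 to compound 3 (beyond the scatter), is modest and concerns a different place, with pyridin-2-yl in place of hydroxy on an amide-type nitrogen. It therefore offers only a loose guide to size. Compound 2 at 90.1% shows that much higher numbers occur among these compounds, so a modest rise seems more likely than a fall, though with wide uncertainty.

The expected change is a number 14.9 percentage points higher from compound 3 to compound 4 (beyond the scatter). For compound 4 the estimated value is 40%, with an expected range of 20% to 70%.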

Compound 4, percent growth inhibition at one concentration: 74.5%
Compound 4: the middle estimate sits 34.5 percentage points below what was measured; measured number above the stated range.
By their numbers in this assay, from the lowest: compound 1; then compound 3; then compound 4; then compound 2.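

In this assay, the pyridin-2-yl amide proves highly responsive at the ring carbon two atoms from the ring nitrogen: chloro in place of hydrogen there gives a number 49.4 percentage points higher from compound 3 to compound 4 (beyond the scatter). This single added heavy atom, which brings no hydrogen-bond donor or acceptor, produces a large step, whereas the earlier exchange of the whole amide-nitrogen group gave only a modest one, a number 12.7 percentage points higher from compound 1 to compound 3 (beyond the scatter). Nothing available explains why this substitution has such an effect on growth inhibition.

The compounds shown leave open whether the gain is specific to chloro or would also appear with fluoro, bromo, methyl or methoxy on the same carbon. They also do not show whether chloro on another carbon of the ring would give a step of similar size.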